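A Cyclobutyl Amide Carried Over to a Second Core

This account rests on a few compounds, and the source may have more. Where it says the series, first, only, none or still open, it means among the compounds named here.

Compound 1 `CC[C@H]1OC(=O)[C@H](C)[C@@H](O[C@H]2C[C@@](C)(OC)[C@@H](OCCCNC(=O)C3CCC3)[C@H](C)O2)[C@H](C)[C@@H](O[C@@H]2O[C@H](C)C[C@H](N(C)C)[C@H]2O)[C@](C)(O)C[C@@H](C)CN(C)[C@H](C)[C@@H](O)[C@]1(C)O` and compound 2 `CC[C@H]1OC(=O)[C@H](C)[C@@H](O[C@H]2C[C@@](C)(OC)[C@@H](OCCCNC(=O)COC)[C@H](C)O2)[C@H](C)[C@@H](O[C@@H]2O[C@H](C)C[C@H](N(C)C)[C@H]2O)[C@](C)(O)C[C@@H](C)CN(C)[C@H](C)[C@@H](O)[C@]1(C)O` share one core and differ only in the group attached to the amide carbonyl carbon. In a physicochemical assay for lipophilicity, read by HPLC, measured as chromatographic lipophilicity, at pH 7.4 (a lower number here means a more polar compound, a higher number a more lipophilic compound), compound 1 gives 2.62, while compound 2 gives 2.16. The structural difference between them, (cyclobutyl in place of methoxymethyl on a carbonyl carbon), goes with a number 0.46 log units higher from compound 2 to compound 1 (beyond the scatter).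

Compound 3 `CC[C@H]1OC(=O)[C@H](C)[C@@H](OCCCNC(=O)COC)[C@H](C)[C@@H](O[C@@H]2O[C@H](C)C[C@H](N(C)C)[C@H]2O)[C@](C)(O)C[C@@H](C)CN(C)[C@H](C)[C@@H](O)[C@]1(C)O` carries the same methoxymethyl amide as compound 2, but on a different core; the difference between the two cores is not broken down here. In this assay compound 3 gives 1.4, the lowest of the three values, beyond the scatter below compound 2 and further still below compound 1.

Compound 4 `CC[C@H]1OC(=O)[C@H](C)[C@@H](OCCCNC(=O)C2CCC2)[C@H](C)[C@@H](O[C@@H]2O[C@H](C)C[C@H](N(C)C)[C@H]2O)[C@](C)(O)C[C@@H](C)CN(C)[C@H](C)[C@@H](O)[C@]1(C)O` has not yet been measured in this assay. It differs from compound 3 by cyclobutyl in place of methoxymethyl on a carbonyl carbon, the same change that separates compound 2 from compound 1, made at the same kind of place. Among the measured compounds shown here, with one measured instance of this change, the only guide is a number 0.46 log units higher from compound 2 to compound 1 (beyond the scatter), and the step is expected to be of similar size, a number 0.46 log units higher from compound 3 to compound 4 (beyond the scatter), because a number 0.46 log units higher from compound 2 to compound 1 (beyond the scatter) was observed for exactly this exchange. Compound 4 is therefore estimated to give 1.86 in this assay, with the likely range running from 1.55 to 2.15, leaving it well below compound 1 and compound 2 as compound 3 is.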

Compound 4, distribution coefficient: 1.78
Beside the measured number, compound 4's estimate is 0.08 log units above it; the range from low to high includes it.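

In this assay the exchange of methoxymethyl for cyclobutyl on a carbonyl carbon goes with a number 0.38 log units higher from compound 3 to compound 4 (beyond the scatter) and, on the other core, with a number 0.46 log units higher from compound 2 to compound 1 (beyond the scatter), so the change points the same way on both cores and each step is beyond the scatter. Among the compounds shown here, this is only two matched pairs on two cores: it shows that the change carried over once, but not that it would do so on any further core, and it does not break down the difference between the cores themselves. Nothing available here explains the size or the direction of either step.

The compounds shown carry only methoxymethyl or cyclobutyl on the amide carbonyl, which leaves open how a longer chain, a cyclopentyl group, or a group bearing an amine or a carboxylic acid would read in this assay on either core. Also open, on these data alone, is whether the exchange would keep its direction on a third core, and whether it would leave any read-out other than this one unchanged or shift it.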